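Methylamino entering next to the ring nitrogen

The source may report more compounds than this note shows. Statements on the series, on what has been measured and on what is new or still open speak of the compounds shown alone.

Compound 1 `CC(CC(C)(C)C)Oc1cccc2cccnc12` is read in an assay on cells with melanin-concentrating hormone receptor 1 (Homo sapiens) as the target, read by radioligand binding (on this read-out lower numbers stand for stronger inhibition and higher numbers for weaker inhibition), as a limit, > 2000 nM, so it sits at the limit of > 2000 nM in this assay, at which 1 of the 2 values shown sits. Compound 2 `COCC(C)Oc1cccc2ccc(N)nc12` carries an amino group and a different chain; in this assay compound 2 gives 606 nM, a number rather than a limit. Compound 3 `CNc1ccc2cccc(OC(C)CC(C)(C)C)c2n1` differs from compound 1 by methylamino in place of hydrogen on an aromatic carbon. For the measured compounds named here, no step between compounds differing in one place is measured. A gain beyond the scatter is expected, as compound 2 with its amino group gives 606 nM. In this assay the expected step is an at least 5.0-fold lower number from compound 1 to compound 3 (0.69 log units; beyond the scatter). Compound 3 is estimated at 400 nM, between 120 nM and 1500 nM.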

Compound 3, half-maximal inhibitory concentration: 310 nM
The estimate for compound 3 lay 1.3-fold (0.11 log units) above the measured number; the measured number falls inside the stated range.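

Methylamino in place of hydrogen, on the aromatic carbon next to the ring nitrogen, is the first single change readable in the series: in this assay it gives an at least 6.4-fold lower number from compound 1 to compound 3 (0.80 log units; beyond the scatter). With the chain of compound 1 kept, compound 3 now gives a number rather than a limit, so this gain does not depend on the chain of compound 2. On these data alone, compound 1 stands only as a limit, so the full size of the step stays unknown: the limit of > 2000 nM in this assay, at which 1 of the 3 values shown sits.

As far as these compounds go, whether dimethylamino or ethylamino on this carbon would read differently from methylamino remains open. So does whether methylamino gives a similar step with a shorter or longer chain.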